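Naphthyl carbinol ethers: moving from compound 2 toward compound 3

The compounds below may be only part of what the source reports. "The series", "measured", "known", "first", "only" and "open" are said of these compounds alone.

Compound 1, `COc1ccc(C(O)(Cc2ccc(F)cc2)c2cccc3ccccc23)c(OC)c1OC`, in a functional assay on MDA-MB-231 cells (Homo sapiens) for inhibition, read by sulforhodamine B assay, with a stated time of 48 h (on this read-out lower numbers stand for stronger inhibition and higher numbers for weaker inhibition), gives compound 1 a value of 5440 nM. Compound 2, `COc1cc(COC(c2ccc(OC)c(OC)c2OC)c2cccc3ccccc23)cc(OC)c1`, carries the benzyl group on the oxygen instead of on the central carbon. In this assay compound 2 returns only a limit, > 20000 nM, not a measured number. That limit is part of the picture: the limit of > 20000 nM in this assay, at which 1 of the 2 values shown sits. Among the measured compounds shown here, because compound 2 sits at the limit of > 20000 nM in this assay, at which 1 of the 2 values shown sits, its true value is unknown beyond that bound, and compound 1 is the only compound here with a definite number.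

Compound 3, `COc1ccc(C(OCc2ccc(C)cc2)c2cccc3ccccc23)c(OC)c1OC`, keeps the ether arrangement of compound 2 and alters the benzyl part: 4-methylphenyl in place of 3,5-dimethoxyphenyl on a saturated chain carbon bound to an oxygen on a saturated carbon. For the measured compounds named here, no measured step connects compound 2 to any other compound, so the size of this change in this assay is an open question. The expectation is a modest shift, possibly toward stronger inhibition, but not one that clearly passes the scatter, so an at least 1.3-fold lower number from compound 2 to compound 3 (0.12 log units; that floor lies within the scatter) is expected. Compound 3 is estimated at 15000 nM, within a range from 5000 nM to 40000 nM.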

Compound 3, half-maximal inhibitory concentration: > 20000 nM
Compound 3: no number, only a limit; the forecaster's own chance of this, stated with the estimate: 45%; middle value at least 1.3-fold (0.12 log units) from the limit.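

In this assay compound 3 returns only a limit, > 20000 nM, not a number. Compound 2 also stands at a limit, so no step from one to the other can be read: the limit of > 20000 nM in this assay, at which 2 of the 3 values shown sit.

The compounds shown leave open where the true values of compound 2 and compound 3 lie, and whether 4-methylphenyl in place of 3,5-dimethoxyphenyl changes inhibition at all.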